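The source may report more compounds than this note shows. Statements on the series, on what has been measured and on what is new or still open speak of the compounds shown alone.

Measured in an ADME assay on a cell-free system (plasma, Homo sapiens) for metabolic stability, read by LC-MS; on this read-out lower numbers stand for a shorter-lived compound and higher numbers for a longer-lived compound:

- Compound 1 `NCc1ccc(C(=O)Nc2ccncc2)cc1-c1cccc(C(=O)OCC2CCCCC2)c1`: 1.65 h
- Compound 2 `NCc1ccc(C(=O)Nc2ccncc2F)cc1-c1cccc(C(=O)OCC2CCCO2)c1`: < 0.0834 h, a limit of the assay
- Compound 3 `CC(C)OCCOC(=O)c1cccc(-c2cc(C(=O)Nc3ccncc3F)ccc2CN)c1`: 0.1 h

Compound 1 stands highest of the numbers, beyond the scatter above compound 3. Compound 4 `COC(=O)c1cccc(-c2cc(C(=O)Nc3ccncc3)ccc2CN)c1` departs from compound 1 at the ester: hydrogen in place of cyclohexyl on a saturated chain carbon bound to an oxygen next to a carbonyl group, so that cyclohexylmethoxycarbonyl becomes methoxycarbonyl. Among the measured compounds shown here, the only measured step, an at least 1.1-fold higher number from compound 2 to compound 3 (0.07 log units; that floor lies within the scatter), swaps other groups at that same place, and it gives no size for this change. Without the cyclohexyl, compound 3 reads 0.1 h, though its core also differs, so a drop is expected in this assay. The estimated step is a 4.1-fold lower number from compound 1 to compound 4 (0.62 log units; beyond the scatter). Compound 4 is expected at 0.4 h, with an estimated range of 0.1 h to 1.6 h.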

Compound 4, half-life: 1.52 h
For compound 4 the middle estimate is 3.8-fold (0.58 log units) below the measured one; the measured number falls inside the stated range.
By their numbers in this assay, from the lowest: compound 3; then compounds 4 and 1 (each within the scatter of the next). At a limit, below all of these: compound 2.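

In this assay, the change from cyclohexylmethoxycarbonyl to methoxycarbonyl gives a 1.1-fold lower number from compound 1 to compound 4 (0.04 log units; within the scatter), so on the core of compound 1 the cyclohexyl can go without a difference that stands out from the scatter. Among the compounds shown here, the one earlier step at this place gave no size for this change. Nothing measured here bears on the cause of this result.

On these data alone, it remains open how a longer chain in place of the methyl, or a carboxylic acid in place of the ester, would read. Also open, as far as these compounds go, is whether the same change behaves alike on the core of compound 3.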